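This account rests on a few compounds, and the source may have more. Where it says the series, first, only, none or still open, it means among the compounds named here.

Compound 2 `CN(C[C@@H]1[C@H](NC(=O)/C(=N\OC(C)(C)C(=O)O)c2csc(N)n2)C(=O)N1S(=O)(=O)O)C(=O)CN` gives 212 h in a physicochemical assay for metabolic stability, read by HPLC and mass spectrometry, in phosphate buffer, at 37 degrees C, at pH 7.4 (on this read-out lower numbers stand for a shorter-lived compound and higher numbers for a longer-lived compound), the highest of the two numbers shown. The nearest is compound 1 `CC(C)(O/N=C(\C(=O)N[C@@H]1C(=O)N(S(=O)(=O)O)[C@@H]1CNC(=O)CN)c1csc(N)n1)C(=O)O`, which gives 149 h in this assay; the step of a 1.4-fold higher number from compound 1 to compound 2 (0.15 log units; within the scatter) stays within the scatter. For compound 3 `CC(C)(O/N=C(\C(=O)N[C@@H]1C(=O)N(S(=O)(=O)O)[C@@H]1CN1C[C@@H](CNC(=N)N)OC1=O)c1csc(N)n1)C(=O)O` this assay returns only a limit, > 37 h. The steps a step that the limit leaves unreadable from compound 1 to compound 3 and a step that the limit leaves unreadable from compound 2 to compound 3 cannot be sized because of the limit of > 37 h in this assay, at which 1 of the 3 values shown sits. Compound 4 `CC(C)(O/N=C(\C(=O)N[C@@H]1C(=O)N(S(=O)(=O)O)[C@@H]1Cn1cc(CO)nn1)c1csc(N)n1)C(=O)O` differs from compound 2 by 4-(hydroxymethyl)-1H-1,2,3-triazol-1-yl in place of ((aminomethyl)carbonyl)(methyl)amino on a saturated chain carbon bound to a saturated ring carbon. Among the measured compounds shown here, the only readable step, from compound 1 to compound 2, lies within the scatter, and the two unreadable steps give no direction, so little movement is expected. The step of a 1.2-fold lower number from compound 2 to compound 4 (0.10 log units; within the scatter) is therefore expected to stay within the scatter. Compound 4 is estimated at 170 h, between 60 h and 450 h.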

Compound 4, half-life: > 37 h
Compound 4 ended at the assay's limit (the forecaster's own chance of this, stated with the estimate: 30%); the middle value lies beyond the limit too.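

No step from compound 1, compound 2 or compound 3 to compound 4 can be read in this assay, where compound 4 returns only a limit: the limit of > 37 h in this assay, at which 2 of the 4 values shown sit.

The compounds shown leave open how long compound 3 and compound 4 actually last, and whether 4-(hydroxymethyl)-1H-1,2,3-triazol-1-yl shifts the half-life at all.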